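Extending a Side Chain in a Pancreatic Cell Assay

A few compounds are considered here, and "the series" means these few. Any claim that something is new, unique, unknown or untested is made for them only; others in the source may bear on it.

Measured so far:
- compound 1, `CC(C)=CCC1Cc2c(OCCCNS(=O)(=O)c3ccc(Cl)cc3)cc(=O)n(CCCO)c2CC1(C)C`: 24.7%
- compound 2, `CC(C)=CCC1Cc2c(OCCCNS(=O)(=O)c3ccc(Br)cc3)cc(=O)n(CCCO)c2CC1(C)C`: 19.5%
- compound 3, `CC(C)=CCC1Cc2c(OCCCOc3ccc([N+](=O)[O-])cc3)cc(=O)n(CCCO)c2CC1(C)C`: 47.5%

In a functional assay on PANC-1 cells (Homo sapiens) for inhibition, read by MTT assay, with a stated time of 24 h, tested at 10 uM (a higher number here means more inhibition at the concentration tested (going by the name of the read-out), a lower number less inhibition), compound 1 gives 24.7%, the second highest of the three numbers. Compound 2 lies close to it: a number 5.2 percentage points lower from compound 1 to compound 2 (within the scatter). Compound 3 stands furthest away: a number 22.8 percentage points higher from compound 1 to compound 3 (beyond the scatter), and in the same direction a number 28 percentage points higher from compound 2 to compound 3 (beyond the scatter). All three measured steps alter the group at the far end of the chain attached through the ring oxygen; none of them touches any other part of the shared core.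

Compound 4, `CC(C)=CCC/C(C)=C/CC1Cc2c(OCCCNS(=O)(=O)c3ccc(Cl)cc3)cc(=O)n(CCCO)c2CC1(C)C`, is built from compound 1 by a change elsewhere: 3-methylbut-2-en-1-yl in place of hydrogen on a saturated chain carbon bound to a double-bonded chain carbon. The chain bearing the sulfonamide is kept exactly as in compound 1. Within the data shown here, no measured pair varies the part of the molecule that is changed here, so the measured steps give no direct guidance on its size or direction. With the rest of the structure identical to compound 1 at 24.7%, the expectation is a step that stays within the scatter: a number 0.3 percentage points higher from compound 1 to compound 4 (within the scatter). Compound 4 is therefore estimated at 25%, with a range from 8% to 42%.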

Compound 4, a percentage reported as inhibition, at one concentration (the size of the read-out at that concentration, not a potency): 14.5%
Beside the measured number, compound 4's estimate is 10.5 percentage points above it; low and high end bracket the measured number.
By their numbers in this assay, from the lowest: compounds 4, 2 and 1 (each within the scatter of the next, the first and the last beyond it); then compound 3.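

Turning the 3-methylbut-2-en-1-yl group into 3,7-dimethylocta-2,6-dien-1-yl gives a number 10.2 percentage points lower from compound 1 to compound 4 (beyond the scatter) in this assay and is the first measured change that leaves the end of the chain attached through the ring oxygen untouched. The read-out therefore responds to this part of the molecule as well, and in this one step the added 5 carbon atoms go with less inhibition, not more. Nothing measured here explains why the number falls, so only the size and direction of the step can be stated.

On these data alone, with a single step at this position, it stays open whether the trend follows chain length, since a methyl group or a saturated 3,7-dimethyloctyl chain in the same place would be needed to separate length from the added double bond. As far as these compounds go, it is also open whether the same lengthening would lower the number when the chain attached through the ring oxygen ends in 4-nitrophenoxy instead of the sulfonamide kept here.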